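Series notes: fluoro for trifluoromethyl on the aryl ring

The source may report more compounds than this note shows. Statements on the series, on what has been measured and on what is new or still open speak of the compounds shown alone.

Measured compounds:
compound 1 `Cc1ccc(C(=O)n2c(-c3cn(-c4ccccc4)nc3-c3ccc(C(F)(F)F)cc3)nc3ccccc32)cn1`, 153000 nM
compound 2 `O=C(c1cccnc1)n1c(-c2cn(-c3ccccc3)nc2-c2ccc(C(F)(F)F)cc2)nc2ccccc21`, 158000 nM

In an ADME assay on HEK-293T cells (Homo sapiens) for cytotoxicity, read by MTT assay, with a stated time of 24 h (a lower number here means that less compound is tolerated, a higher number that more compound is tolerated), compound 1 gives 153000 nM and compound 2 gives 158000 nM. Within the data shown here, compound 1 is one of only two measured compounds, and its number cannot be told apart from that of compound 2: the step of a 1.0-fold higher number from compound 1 to compound 2 (0.01 log units; within the scatter) is within the scatter. Nothing in the measured pair therefore separates one compound from the other in this assay.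

Compound 3 `Cc1ccc(C(=O)n2c(-c3cn(-c4ccccc4)nc3-c3ccc(F)cc3)nc3ccccc32)cn1` is not yet measured. It differs from compound 1 as follows: fluoro in place of trifluoromethyl on an aromatic carbon.

Among the measured compounds shown here, no measured step concerns this position; the only measured step, a 1.0-fold higher number from compound 1 to compound 2 (0.01 log units; within the scatter), changes a different part of the molecule and is itself within the scatter. There is thus no basis for expecting a move beyond the scatter from compound 1 to compound 3, and the expected step is a 1.0-fold lower number from compound 1 to compound 3 (0.01 log units; within the scatter). The estimate for compound 3 in this assay is 150000 nM, with a range from 75000 nM to 300000 nM; numbers this high may also come back as a limit of the assay rather than as a value.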

Compound 3, half-maximal cytotoxic concentration: 137000 nM
Beside the measured number, compound 3's estimate is 1.1-fold (0.04 log units) above it; measured number inside the range.
By their numbers in this assay, from the lowest: compounds 3, 1 and 2 (each within the scatter of the next).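

In this assay, among these compounds, the change from 4-(trifluoromethyl)phenyl to 4-fluorophenyl gives a 1.1-fold lower number from compound 1 to compound 3 (0.05 log units; within the scatter) and so provides the first measured step at this position, since the earlier pair spoke only to the methyl in another part of the molecule. Going from the four heavy atoms of trifluoromethyl to the single heavy atom of fluoro, on an aromatic carbon para to a large group, therefore leaves the number within the scatter on the background of compound 1. No measurement at hand speaks to the reason for this outcome.

It remains open whether the number at this position would stay within the scatter with an amine, a carboxylic acid or a longer chain on the same aromatic carbon, as trifluoromethyl and fluoro are the only groups shown there. Also open, as far as these compounds go, is whether the same change would read alike on the background of compound 2, which carries hydrogen in place of the methyl.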